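Chain length step from compound 2 to compound 4

This account rests on a few compounds, and the source may have more. Where it says the series, first, only, none or still open, it means among the compounds named here.

Measured compounds:
compound 1 `NC(C(=O)NCC(=O)Nc1ccc(Cl)cc1C(=O)c1ccccc1)c1ccccc1`: 28 mg/kg
compound 2 `CCCC(=O)NCC(=O)N(C)c1ccc(Cl)cc1C(=O)c1ccccc1Cl`: 0.98 mg/kg
compound 3 `CCCCCC(=O)NCC(=O)N(C)c1ccc(Cl)cc1C(=O)c1ccccc1Cl`: 1.9 mg/kg

In a functional assay on the whole organism for antagonist activity, with Mus musculus as the target (a higher number here means that more compound is needed for the effect, a lower number that less compound is needed), compound 2 gives 0.98 mg/kg, the lowest of the three numbers. Compound 1 gives 28 mg/kg, far beyond the scatter from compound 2, whereas compound 3 gives 1.9 mg/kg, within the scatter of compound 2. Compound 4 `CCCCC(=O)NCC(=O)N(C)c1ccc(Cl)cc1C(=O)c1ccccc1Cl` differs from compound 2 by methyl in place of hydrogen on a saturated chain carbon, three bonds along the chain from a carbonyl carbon. Among the measured compounds shown here, the one measured step that bears on this change is a 1.9-fold higher number from compound 2 to compound 3 (0.29 log units; within the scatter), the same difference cut one bond further out. That step stayed within the scatter, so for compound 4 no shift beyond the scatter is expected in this assay. Compound 4 is therefore expected to give 1.4 mg/kg, with a range from 0.6 mg/kg to 3.5 mg/kg, a step of a 1.4-fold higher number from compound 2 to compound 4 (0.15 log units; within the scatter) that is expected to remain within the scatter.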

Compound 4, dose for half-maximal effect: 1.3 mg/kg
Beside the measured number, compound 4's estimate is 1.1-fold (0.03 log units) above it; low and high end bracket the measured number.
By their numbers in this assay, from the lowest: compounds 2, 4 and 3 (each within the scatter of the next); then compound 1.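

In this assay, methyl in place of hydrogen at this saturated chain carbon amounts to a small step (a 1.3-fold higher number from compound 2 to compound 4 (0.12 log units; within the scatter)), and the comparison with the ethyl of compound 3 is just as small (a 1.5-fold lower number from compound 3 to compound 4 (0.16 log units; within the scatter)). Compounds 2, 4 and 3 therefore cannot be told apart, and methyl now joins ethyl as a change that stays within the scatter here. No evidence on a cause is at hand. Still open, as far as these compounds go, is whether a longer chain, an amine or a carboxylic acid at this place would move the number beyond the scatter.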